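Swapping the aryl group on the triazole nitrogen

A few compounds are considered here, and "the series" means these few. Any claim that something is new, unique, unknown or untested is made for them only; others in the source may bear on it.

Compound 1 `COc1ccccc1-n1cc(COc2c(/C=C\C(=O)O)ccc(OC)c2CC=C(C)C)nn1` and compound 2 `COc1ccc(/C=C\C(=O)O)c(OCc2cn(-c3ccc(C#N)cc3)nn2)c1CC=C(C)C` share a core and differ only in the aryl group carried on a ring nitrogen. In a functional assay on A-431 cells (Homo sapiens) for cytotoxicity, read by MTT assay, with a stated time of 24 h (a lower number here means a stronger inhibitor, a higher number a weaker inhibitor), compound 1 gives 32600 nM, and compound 2 gives 23000 nM. The step of a 1.4-fold lower number from compound 1 to compound 2 (0.15 log units; within the scatter) is too small to read as a real change, so compound 2 simply has the lower of the two numbers.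

Compound 3 `COc1ccc(/C=C\C(=O)O)c(OCc2cn(-c3ccccc3F)nn2)c1CC=C(C)C` changes the same position once more: 2-fluorophenyl in place of 4-cyanophenyl on an aromatic nitrogen. Within the data shown here, the only measured step that bears on it, the change from compound 1 to compound 2, also swapped the aryl group on this nitrogen and moved the number by little. The aryl change from compound 2 to compound 3 is therefore expected to give no step beyond the scatter, and the estimated step of a 1.1-fold higher number from compound 2 to compound 3 (0.04 log units; within the scatter) reflects that. Compound 3 is expected to give about 25000 nM in this assay, within a range from 10000 nM to 60000 nM.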

Compound 3, half-maximal inhibitory concentration: 12400 nM
Compound 3: middle estimate off by 2.0-fold (0.30 log units), on the high side, within the range that was stated.
By their numbers in this assay, from the lowest: compounds 3, 2 and 1 (each within the scatter of the next, the first and the last beyond it).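

Among the aryl groups on this aromatic nitrogen, one change now gives a step beyond the scatter: in this assay, fluoro in place of methoxy on an aromatic carbon gives a 2.6-fold lower number from compound 1 to compound 3 (0.42 log units; beyond the scatter), which is a modest step. By contrast, 2-fluorophenyl in place of 4-cyanophenyl gives a 1.9-fold lower number from compound 2 to compound 3 (0.27 log units; within the scatter), so these two groups cannot be told apart here. The position therefore responds at least a little to the choice of aryl group, but no available measurement explains this response.

The compounds shown leave open whether the fluoro group would give a similar number from another place on the ring, as in 4-fluorophenyl. Also open, from the compounds shown here alone, is how this nitrogen would tolerate an aryl group carrying an amine, such as 4-aminophenyl, or a non-aromatic group such as cyclohexyl.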